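Working notes: hydroxy in place of methyl in compound 3

The source may hold more compounds than are shown below. What is called first, only, known or untested is meant among the compounds shown, and "the series" means these compounds.

Measured in a functional assay on A2780 cells (Homo sapiens) for antiproliferative activity, read by CellTiter-Glo, with a stated time of 4 days; on this read-out higher numbers stand for weaker inhibition and lower numbers for stronger inhibition:
- compound 1 `Nc1ccc(CNC(=O)Nc2ccc(CN3C(=O)c4ccccc4C3=O)cc2)cn1`: 7 nM
- compound 2 `CCC(=O)N[C@@H](C)c1ccc(NC(=O)[C@H]2C[C@@H]2c2cccnc2)cc1`: 5 nM
- compound 3 `CC[C@H](NC(=O)c1ccccc1)c1ccc(NC(=O)[C@H]2C[C@@H]2c2cccnc2)cc1`: 43 nM

Not yet measured: compound 4 `O=C(N[C@@H](CO)c1ccc(NC(=O)[C@H]2C[C@@H]2c2cccnc2)cc1)c1ccccc1`.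

In this assay compound 3 carries the highest number of the three, and so the weakest inhibition. Its gaps to the other two both lie beyond the scatter. The next step leads from compound 3 to compound 4: hydroxy in place of methyl on a saturated chain carbon, two bonds along the chain from an amide-type nitrogen and an aromatic carbon. This places hydroxy in place of methyl on a saturated chain carbon, two bonds along the chain from an amide-type nitrogen and an aromatic carbon. Cut one bond further out, the same difference reads ethyl to hydroxymethyl.

Within the data shown here, no two measured compounds differ in one place only, so the data give no direct measure of this change. The expectation therefore starts from compound 3 at 43 nM and is for no step beyond the scatter in this assay. The estimated step is a 1.4-fold lower number from compound 3 to compound 4 (0.16 log units; within the scatter). The uncertainty remains wide, and a larger move in either direction cannot be excluded. For compound 4 the expected value is 30 nM, with an estimated range from 10 nM to 90 nM.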

Compound 4, half-maximal inhibitory concentration: 200 nM
Compound 4: the middle estimate sits 6.7-fold (0.82 log units) below what was measured, and the stated range ends below it.
By their numbers in this assay, from the lowest: compounds 2 and 1 (each within the scatter of the next); then compound 3; then compound 4.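

Among these compounds, this is the first single-place comparison: in this assay hydroxy in place of methyl on a saturated chain carbon, two bonds along the chain from an amide-type nitrogen and an aromatic carbon, gives a 4.7-fold higher number from compound 3 to compound 4 (0.67 log units; beyond the scatter) and so shows that the number at this position responds to the change. Ethyl to hydroxymethyl, which adds one hydrogen-bond donor and one hydrogen-bond acceptor, therefore goes with weaker inhibition here, though this rests on a single pair. Nothing available accounts for the loss.

As far as these compounds go, whether the loss is specific to hydroxy or would also appear with a methoxy, an amine or a carboxylic acid on this chain remains open. From the compounds shown here alone, it is also open how a longer chain at this carbon would compare.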